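Moving a hydroxyl round one aryl of a triaryl core

A few compounds are considered here, and "the series" means these few. Any claim that something is new, unique, unknown or untested is made for them only; others in the source may bear on it.

Compound 3 `Oc1ccc(-c2cc(-c3cccc(O)c3)cc(-c3cccc(O)c3)n2)cc1` sits second highest of the three numbers in a functional assay on T47D cells (Homo sapiens) for cytotoxicity, read by CCK-8 assay, with a stated time of 4 days (a higher number here means a weaker inhibitor, a lower number a stronger inhibitor), giving 3920 nM. Compound 2 `Oc1ccc(-c2cc(-c3ccc(O)cc3)nc(-c3ccc(O)cc3)c2)cc1` gives 4270 nM in this assay, a value that lies within the scatter of compound 3; compound 1 `Oc1ccc(-c2cc(-c3ccccc3O)cc(-c3cccc(O)c3)n2)cc1` gives 650 nM. Among the compounds with values here, the only single step measured, a 6.0-fold higher number from compound 1 to compound 3 (0.78 log units; beyond the scatter), concerns a different position of the hydroxyl. Compound 4 `Oc1ccc(-c2cc(-c3ccc(O)cc3)nc(-c3cccc(O)c3)c2)cc1` differs from compound 3 by 4-hydroxyphenyl in place of 3-hydroxyphenyl on an aromatic carbon. Since compound 2, which carries two such exchanges relative to compound 3, shows no change beyond the scatter, the expected step of a 1.0-fold higher number from compound 3 to compound 4 (0.01 log units; within the scatter) is small, no direction claimed. The estimate for compound 4 in this assay is 4000 nM, with a range from 1500 nM to 10000 nM.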

Compound 4, half-maximal inhibitory concentration: 4470 nM
Compound 4: the middle estimate sits 1.1-fold (0.05 log units) below what was measured; the range from low to high includes it.
By their numbers in this assay, from the lowest: compound 1; then compounds 3, 2 and 4 (each within the scatter of the next).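

In this assay, 4-hydroxyphenyl and 3-hydroxyphenyl opposite the ring nitrogen cannot be told apart (a 1.1-fold higher number from compound 3 to compound 4 (0.06 log units; within the scatter)). The same exchange elsewhere on the core also stays within the scatter (a 1.0-fold higher number from compound 2 to compound 4 (0.02 log units; within the scatter)). At the position opposite the ring nitrogen, only 2-hydroxyphenyl stands apart, now against 4-hydroxyphenyl as well (a 6.9-fold higher number from compound 1 to compound 4 (0.84 log units; beyond the scatter)).

From the compounds shown here alone, whether an amine or a carboxylic acid at this position would match 2-hydroxyphenyl or the other two groups remains open. Nothing available explains why 2-hydroxyphenyl stands apart.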